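The source may report more compounds than this note shows. Statements on the series, on what has been measured and on what is new or still open speak of the compounds shown alone.

Compound 1, `CCCCCCCCCCCCCCNC(=O)[C@@H](N)[C@@H](C)O`, gives 18700 nM in a functional assay on SW-620 cells (Homo sapiens) for cytotoxicity, read by MTT assay, with a stated time of 48 h; on this read-out lower numbers stand for stronger inhibition and higher numbers for weaker inhibition. Compound 2, `CCCCCCCCCCCCCCNC(=O)[C@@H](NC(=O)/C=C/c1ccccc1)[C@@H](C)O`, gives 200000 nM in this assay.

Compound 2 stands at the highest of the two numbers; the step of an 11-fold higher number from compound 1 to compound 2 (1.03 log units; beyond the scatter) is large. Compound 3, `C/C=C/C=C/C(=O)N[C@H](C(=O)NCCCCCCCCCCCCCC)[C@@H](C)O`, differs from compound 2 by prop-1-en-1-yl in place of phenyl on a double-bonded chain carbon bound to a double-bonded chain carbon. Going by the values given here, no measured pair shares this change; the one step known, an 11-fold higher number from compound 1 to compound 2 (1.03 log units; beyond the scatter), concerns the whole acyl group and bears on it only loosely. For compound 3 the step is therefore expected to stay within the scatter, a 1.3-fold lower number from compound 2 to compound 3 (0.12 log units; within the scatter). Compound 3 is estimated at 150000 nM, with a range from 50000 nM to 400000 nM.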

Compound 3, half-maximal inhibitory concentration: 200000 nM
Beside the measured number, compound 3's estimate is 1.3-fold (0.12 log units) below it; the range from low to high includes it.
By their numbers in this assay, from the lowest: compound 1; then compounds 2 and 3 (each within the scatter of the next).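

In this assay, prop-1-en-1-yl in place of phenyl gives no change at the digits printed from compound 2 to compound 3 (within the scatter), so at this place on the chain the aromatic ring of compound 2 is not required for its value. The large rise seen on acylating the amine nitrogen also appears with (penta-1,3-dien-1-yl)carbonyl, as an 11-fold higher number from compound 1 to compound 3 (1.03 log units; beyond the scatter), so it is not particular to (2-phenylethenyl)carbonyl. Nothing available gives a reason for this result. On these data alone, whether a small acyl group such as acetyl on that nitrogen acts the same way remains open. So does whether a carboxylic acid or an amine at the end of the acyl chain would bring the number back towards that of compound 1.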